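Removing the dimethylcarbamoyl group from compound 3

The source may hold more compounds than are shown below. What is called first, only, known or untested is meant among the compounds shown, and "the series" means these compounds.

Compound 1 `Cn1cc(-c2cnc(NCc3c(F)ccc4c3CCO4)c3cn[nH]c(=O)c23)cn1` gives 2.7
Compound 2 `Cc1nc(CO)ccc1-c1cnc(NCc2c(F)ccc3c2CCO3)c2cn[nH]c(=O)c12` gives 2.4
Compound 3 `CN(C)C(=O)c1cc(-c2cnc(NCc3c(F)ccc4c3CCO4)c3cn[nH]c(=O)c23)n(C)n1` gives 2.1

All three compounds were measured in a physicochemical assay for lipophilicity, using the shake flask method, in phosphate buffer, measured as octanol-water partition, with a stated time of 30 min, at pH 7.4 (a lower number here means a more polar compound, a higher number a more lipophilic compound), and share one core. Compound 3 (2.1) stands at the low end of these numbers, although only its step from compound 1 lies beyond the scatter. The next structure is compound 4 `Cc1cc(-c2cnc(NCc3c(F)ccc4c3CCO4)c3cn[nH]c(=O)c23)n(C)n1`, which has methyl in place of dimethylcarbamoyl on an aromatic carbon of a five-membered aromatic ring with 2 nitrogen (methyl in place of dimethylcarbamoyl on an aromatic carbon).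

The closest guide is the replacement of 1-methyl-1H-pyrazol-4-yl by 3-(dimethylcarbamoyl)-1-methyl-1H-pyrazol-5-yl, which gave a number 0.60 log units lower from compound 1 to compound 3 (beyond the scatter). Replacing 6-(hydroxymethyl)-2-methylpyridin-3-yl by the same group gave a smaller change, a number 0.30 log units lower from compound 2 to compound 3 (within the scatter). For the measured compounds named here, no measured pair isolates the loss of dimethylcarbamoyl, so the guide is indirect. Compound 4 lacks that group, so a modest rise in this assay is expected, of about the size seen in the comparison with compound 1 (2.7). The expected change is a number 0.70 log units higher from compound 3 to compound 4 (beyond the scatter). The estimate for compound 4 is 2.8. The expected range for that compound runs from 2.4 to 3.2.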

Compound 4, distribution coefficient: 3
Compound 4: the middle estimate sits 0.20 log units below what was measured; measured number inside the range.
By their numbers in this assay, from the lowest: compounds 3, 2, 1 and 4 (each within the scatter of the next, the first and the last beyond it).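

For the compounds shown here, this is the first pair in which dimethylcarbamoyl is the only difference: in this assay, methyl in its place on an aromatic carbon of the five-membered aromatic ring with 2 nitrogen gives a number 0.90 log units higher from compound 3 to compound 4 (beyond the scatter), so the effect of this exchange can now be read directly rather than inferred from changes of the whole ring substituent. The 1,3-dimethyl-1H-pyrazol-5-yl group also stands apart from 6-(hydroxymethyl)-2-methylpyridin-3-yl, with a number 0.60 log units higher from compound 2 to compound 4 (beyond the scatter), whereas its exchange for 1-methyl-1H-pyrazol-4-yl, with a number 0.30 log units higher from compound 1 to compound 4 (within the scatter), does not separate those two groups in this measurement. No supporting measurement bears on why the step from dimethylcarbamoyl to methyl has this size.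

With only methyl and dimethylcarbamoyl shown on this carbon, it remains open where a primary amide, a carboxylic acid, an amine or a longer chain such as ethyl would fall in this assay. As far as these compounds go, it is also open whether the same exchange of dimethylcarbamoyl for methyl would give a step of similar size on a different ring or with a different group on the shared core.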